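This account rests on a few compounds, and the source may have more. Where it says the series, first, only, none or still open, it means among the compounds named here.

In a functional assay on SW480 cells (Homo sapiens) for antiproliferative activity, read by MTT assay, with a stated time of 72 h (a higher number here means a weaker inhibitor, a lower number a stronger inhibitor), compound 1 `CCOC(=O)c1cc(=O)c2cc(CSC(=S)N(C(C)C)C(C)C)ccc2o1` reaches only the assay's limit and gives > 25000 nM. Two other compounds share its thiocarbamate side chain on a different core. Compound 2 `O=c1cc(CSC(=S)N2CCCCC2)oc2cc(Cl)ccc12` gives 2500 nM in this assay. Compound 3 `O=c1cc(CSC(=S)N2CCCC2)oc2cc(Cl)ccc12` gives a limit rather than a number, namely > 25000 nM. Among the measured compounds shown here, the one measured step, an at least 10-fold higher number from compound 2 to compound 3 (1.00 log units; beyond the scatter), is the nearest point of reference, and it sits where the limit of > 25000 nM in this assay, at which 2 of the 3 values shown sit, is reached.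

Compound 4 `CCOC(=O)c1cc(=O)c2cc(CSC(=S)N3CCCC3)ccc2o1` is compound 1 with pyrrolidin-1-yl in place of diisopropylamino on a thiocarbonyl carbon. For the measured compounds named here, no measured pair shows exactly this exchange; the step from compound 2 to compound 3 concerns a piperidin-1-yl rather than a diisopropylamino group, and it moved towards the limit, not away from it. Compound 1 itself starts at the limit, so any step in this assay can only be expected to leave compound 4 at or beyond that limit. The estimated step is therefore a step that the limit leaves unreadable from compound 1 to compound 4, and compound 4 is expected to give about 40000 nM, within 15000 nM to 150000 nM, most probably again reported only as a limit.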

Compound 4, half-maximal inhibitory concentration: > 25000 nM
Compound 4: a limit, no number; the forecaster's own chance of this, stated with the estimate: 85%; the middle value is on the limit's open side.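

No step can be read between compound 1 and compound 4, as both results are limits and not numbers: the limit of > 25000 nM in this assay, at which 3 of the 4 values shown sit.

The compounds shown leave open whether exchanging diisopropylamino for pyrrolidin-1-yl changes activity on the core of compound 1, and how far beyond the limit either compound lies.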